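This account rests on a few compounds, and the source may have more. Where it says the series, first, only, none or still open, it means among the compounds named here.

Measured so far in a functional assay on K562 cells (Homo sapiens) for cytotoxicity, read by trypan blue exclusion, with a stated time of 96 h; a lower number here means a stronger inhibitor, a higher number a weaker inhibitor:
- compound 1 `COc1cc(OC)c(/C=C/S(=O)(=O)Nc2ccc(F)c(N)c2)c(OC)c1`: 5000 nM
- compound 2 `COc1cc(OC)c(/C=C/S(=O)(=O)Nc2ccc(OC)c(O)c2)c(OC)c1`: 15 nM

Compound 2 holds the lower of the two numbers, and the gap to the other compound is beyond the scatter. The next compound, compound 3 `COc1ccc(NS(=O)(=O)/C=C/c2c(OC)cc(OCCCC(=O)O)cc2OC)cc1O`, keeps the sulfonamide part of compound 2 and changes the other end of the molecule: 2-carboxyethyl in place of hydrogen on a saturated chain carbon bound to an oxygen on an aromatic ring. In words, 2-carboxyethyl stands in place of hydrogen on a saturated chain carbon bound to an oxygen on an aromatic ring, so a methoxy becomes 3-carboxypropoxy.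

For the measured compounds named here, only one measured step exists, a 330-fold lower number from compound 1 to compound 2 (2.52 log units; beyond the scatter), a large one. It concerns the group on the sulfonamide nitrogen, not this place, so it bears only indirectly. It shows that one change can move the number far in this series, while the data hold no test of the methoxy group. Starting from the lower of the two numbers, a moderate move to a higher number seems the likelier outcome, with wide uncertainty.

The expected change is a 10-fold higher number from compound 2 to compound 3 (1.00 log units; beyond the scatter). For compound 3 the estimated value is 150 nM, with an expected range from 20 nM to 2000 nM.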

Compound 3, half-maximal inhibitory concentration: 10000 nM
Estimate against measurement, compound 3: 67-fold (1.82 log units) below, outside the stated range (above it).
By their numbers in this assay, from the lowest: compound 2; then compounds 1 and 3 (each within the scatter of the next).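

In this assay the methoxy of compound 2 proves to be no indifferent place: exchanging it for 3-carboxypropoxy, with 2-carboxyethyl in place of hydrogen on a saturated chain carbon bound to an oxygen on an aromatic ring, gives a 670-fold higher number from compound 2 to compound 3 (2.82 log units; beyond the scatter) while the group on the sulfonamide nitrogen stays the same. For the compounds shown here, until now the only measured step was a 330-fold lower number from compound 1 to compound 2 (2.52 log units; beyond the scatter) at that nitrogen, and the new step shows that the other end of the molecule can also move the number by a large amount, here towards a weaker inhibitor. No measurement at hand bears on what lies behind this rise.

The compounds shown leave open whether the rise belongs to the carboxylic acid, to the longer chain, or to the two together, since this single change brings in both at once. A plain butoxy chain, a methyl ester of the same acid, a shorter carboxymethoxy group or a chain ending in an amine would each separate these readings, and none of them stands among the compounds here.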